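Trading chloro for hydrogen on compound 3

The source may hold more compounds than are shown below. What is called first, only, known or untested is meant among the compounds shown, and "the series" means these compounds.

Measured in a functional assay on HeLa cells (Homo sapiens) for inhibition, read by MTT assay, with a stated time of 48 h; on this read-out lower numbers stand for stronger inhibition and higher numbers for weaker inhibition:
- Compound 1 `O=C(/C=C/c1ccc(Cl)cc1)c1ccc[nH]1` gives 25000 nM
- Compound 2 `O=C(/C=C/c1ccccc1Cl)c1ccco1` gives 26000 nM
- Compound 3 `O=C(/C=C/c1ccc(Cl)cc1)c1ccco1` gives 38000 nM

These three values sit close together. Compound 3 lies within the usual scatter of both compound 1 and compound 2, so the numbers do not separate it from either one.

The next compound is compound 4 `O=C(/C=C/c1ccccc1)c1ccco1`. It has hydrogen in place of chloro on an aromatic carbon.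

Only one measured step links two of these compounds by a single change: a 1.5-fold higher number from compound 1 to compound 3 (0.18 log units; within the scatter). That step is small, but it swaps the group on the carbonyl carbon and leaves the chloro in place. Among the compounds with values here, no measured pair shows what losing the chloro does, so the evidence here is indirect. All three values do lie close together, which gives no reason to expect a large move in this assay, and no direction can be favoured.

The expected change is a 1.1-fold higher number from compound 3 to compound 4 (0.02 log units; within the scatter), which means no step beyond the scatter.

For compound 4 the estimated value is 40000 nM, with an expected range from 15000 nM to 100000 nM.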

Compound 4, half-maximal inhibitory concentration: > 100000 nM
Compound 4 ended at the assay's limit; the forecaster's own chance of this, stated with the estimate: 15%; at least 2.5-fold (0.39 log units) between middle value and limit.
By their numbers in this assay, from the lowest: compounds 1, 2 and 3 (each within the scatter of the next). At a limit, above all of these: compound 4.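

In this assay compound 4, which carries hydrogen where the others carry chloro, stands at a limit of the assay and not at a number: the limit of > 100000 nM in this assay, at which 1 of the 4 values shown sits.

All the earlier compounds carry a chloro, so they could not show what happens without it, and here the change does register: replacing the chloro para to a group of 9 heavy atoms gives an at least 2.6-fold higher number from compound 3 to compound 4 (0.42 log units; beyond the scatter), and the same swap at the other chloro placement shown gives an at least 3.8-fold higher number from compound 2 to compound 4 (0.58 log units; beyond the scatter). Both steps lie beyond the scatter, so in this small set, inhibition is weaker with hydrogen on the ring than with chloro at either placement, and the true size of each step may be larger than printed.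

The limit hides how weak compound 4 really is, and the set does not show whether the same loss would follow in the pyrrole-bearing compound 1. It also leaves open whether chloro itself matters or whether another group on that carbon, such as fluoro, methoxy or an amine, would serve equally well.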